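Stripping the Saturated Ring Carbon: an Expectation for Compound 4

The source may hold more compounds than are shown below. What is called first, only, known or untested is meant among the compounds shown, and "the series" means these compounds.

Compound 2 `CCC1CS(=O)(=O)c2cc(C(=O)N=C(N)N)c(C)cc21` gives 24 nM in an assay on cells for inhibition of sodium/hydrogen exchanger (Oryctolagus cuniculus); a higher number here means a weaker inhibitor, a lower number a stronger inhibitor; among the three measured compounds it stands second highest, with compound 1 `CCC1(O)CS(=O)(=O)c2cc(C(=O)N=C(N)N)c(C)cc21` at 34 nM nearest and compound 3 `Cc1cc2c(cc1C(=O)N=C(N)N)S(=O)(=O)C(C)(C)C2C` at 14 nM furthest, both within the scatter of compound 2. Compound 4 `Cc1cc2c(cc1C(=O)N=C(N)N)S(=O)(=O)CC2` differs from compound 2 by hydrogen in place of ethyl on a saturated ring carbon. Within the data shown here, the only single-point step measured on that saturated ring carbon is a 1.4-fold lower number from compound 1 to compound 2 (0.15 log units; within the scatter), within the scatter; compound 3 carries further alkyl groups on the same ring and still sits within the scatter of compound 2. Nothing measured here shows the ring substituents moving the numbers beyond the scatter, so no step beyond the scatter is expected for compound 4 in this assay, a 1.5-fold higher number from compound 2 to compound 4 (0.16 log units; within the scatter). Compound 4 is estimated at 35 nM, ranging from 12 nM to 100 nM.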

Compound 4, half-maximal inhibitory concentration: 60 nM
The estimate for compound 4 lay 1.7-fold (0.23 log units) below the measured number, and the stated range covers the measured number.
By their numbers in this assay, from the lowest: compounds 3, 2, 1 and 4 (each within the scatter of the next, the first and the last beyond it).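

In this assay, among these compounds, the step of a 2.5-fold higher number from compound 2 to compound 4 (0.40 log units; beyond the scatter) is the first beyond the scatter seen on this saturated ring carbon, two ring bonds from the ring sulfur. Replacing ethyl with hydrogen therefore registers at this position, whereas replacing hydroxy with hydrogen in the step to compound 2 did not. No available measurement accounts for this step.

As far as these compounds go, whether a single methyl on this carbon retains the number of compound 2 remains open. So does the outcome with a longer chain such as propyl, or with an amine or a carboxylic acid, at this position.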